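Nitro in Place of Methoxy on a Sulfonyl Ring

The source may report more compounds than this note shows. Statements on the series, on what has been measured and on what is new or still open speak of the compounds shown alone.

Of the compounds shown here, three with a shared core have been measured in a functional assay on Jurkat cells (Homo sapiens) for antiproliferative activity, read by MTT assay and trypan blue exclusion, with a stated time of 72 h; on this read-out higher numbers stand for weaker inhibition and lower numbers for stronger inhibition. Compound 1 `COC(=O)c1ccc(C2SCC(=O)N2c2ccc(N3CCN(Cc4cccc(C)c4)CC3)cn2)c(OC)c1` carries a 3-methylbenzyl group on an amine nitrogen in a ring; in this assay compound 1 gives only a limit, > 100000 nM. Compound 2 `COC(=O)c1ccc(C2SCC(=O)N2c2ccc(N3CCN(S(=O)(=O)c4ccc(F)cc4)CC3)cn2)c(OC)c1` has a (4-fluorophenyl)sulfonyl group there instead, and in this assay compound 2 gives 78300 nM; the change is an at least 1.2-fold lower number from compound 1 to compound 2 (0.10 log units; that floor lies within the scatter). Compound 3 `COC(=O)c1ccc(C2SCC(=O)N2c2ccc(N3CCN(S(=O)(=O)c4ccc(OC)cc4)CC3)cn2)c(OC)c1` carries a (4-methoxyphenyl)sulfonyl group, and in this assay compound 3 gives 45200 nM, the lowest of the two numbers; from the limit the step is an at least 2.2-fold lower number from compound 1 to compound 3 (0.34 log units; beyond the scatter), while the step of a 1.7-fold lower number from compound 2 to compound 3 (0.24 log units; within the scatter) stays within the scatter.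

Compound 4 `COC(=O)c1ccc(C2SCC(=O)N2c2ccc(N3CCN(S(=O)(=O)c4ccc([N+](=O)[O-])cc4)CC3)cn2)c(OC)c1` is the unmeasured member. The change from compound 3 is nitro in place of methoxy on an aromatic carbon. Among the compounds with values here, the only measured step that touches the same aromatic carbon, a 1.7-fold lower number from compound 2 to compound 3 (0.24 log units; within the scatter), was within the scatter, and no step between methoxy and nitro exists in these data. The expected step is therefore a 1.1-fold higher number from compound 3 to compound 4 (0.04 log units; within the scatter), none beyond the scatter. Compound 4 is estimated at 50000 nM, between 15000 nM and 150000 nM.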

Compound 4, half-maximal inhibitory concentration: 54000 nM
Estimate against measurement, compound 4: 1.1-fold (0.03 log units) below; the range from low to high includes it.
By their numbers in this assay, from the lowest: compounds 3, 4 and 2 (each within the scatter of the next). At a limit, above all of these: compound 1.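

With nitro, this aromatic carbon, para to a large group, has now carried three different groups on the sulfonyl ring, and the new steps are a 1.2-fold higher number from compound 3 to compound 4 (0.08 log units; within the scatter) and a 1.5-fold lower number from compound 2 to compound 4 (0.16 log units; within the scatter). Both lie within the scatter, so methoxy, fluoro and nitro cannot be put in any order here, and the change to nitro leaves the number where the earlier sulfonyl compounds stood. Measured from the limit given by compound 1, the step is an at least 1.8-fold lower number from compound 1 to compound 4 (0.26 log units; that floor lies within the scatter), which gives only a floor: the limit of > 100000 nM in this assay, at which 1 of the 4 values shown sits.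

Going by these compounds, whether an amine or a carboxylic acid on this aromatic carbon would keep the number in the same range remains open. So does what an acetyl group, in place of the whole arylsulfonyl group on the amine nitrogen in the ring, would give.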